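Two limits in liver cells and a third aryl group

The compounds below may be only part of what the source reports. "The series", "measured", "known", "first", "only" and "open" are said of these compounds alone.

Compound 2 `COc1ccc(OC)c(-n2nncc2CN2C(=O)C3(C(C#N)=C(N)Oc4c(N)cc5nc6ccccc6nc5c43)c3ccccc32)c1` carries a 2,5-dimethoxyphenyl group on the shared core. In an ADME assay on L02 cells (Homo sapiens) for antiproliferative activity, read by MTT assay, with a stated time of 48 h (on this read-out lower numbers stand for stronger inhibition and higher numbers for weaker inhibition), compound 2 gives > 50000 nM, which is a limit of the assay rather than a measured number. Its nearest measured neighbour is compound 1 `COc1ccccc1-n1nncc1CN1C(=O)C2(C(C#N)=C(N)Oc3c(N)cc4nc5ccccc5nc4c32)c2ccccc21`, which carries a methoxyphenyl group with one methoxy fewer. In this assay compound 1 gives > 50000 nM, again a limit. Going by the values given here, the single change between them, methoxy in place of hydrogen on an aromatic carbon, gives a step that the two limits leave unreadable from compound 1 to compound 2. Every value shown so far sits at the limit of > 50000 nM in this assay, at which 2 of the 2 values shown sit, so no step can be read as a number.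

Compound 3 `N#CC1=C(N)Oc2c(N)cc3nc4ccccc4nc3c2C12C(=O)N(Cc1cnnn1-c1ccc(Cl)cc1[N+](=O)[O-])c1ccccc12` differs from compound 2 in one place: 4-chloro-2-nitrophenyl in place of 2,5-dimethoxyphenyl on an aromatic nitrogen. Among the compounds with values here, no measured step covers this exchange, so the measured pair offers only a weak guide. Because both measured compounds rest at the limit of > 50000 nM in this assay, at which 2 of the 2 values shown sit, compound 3 is expected most likely to return a limit as well. The step that the limit leaves unreadable from compound 2 to compound 3 is thus estimated as no change beyond the scatter. Compound 3 is estimated at 60000 nM, within 20000 nM to 200000 nM.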

Compound 3, half-maximal inhibitory concentration: > 50000 nM
Compound 3 gave a limit, no number; the forecaster's own chance of this, stated with the estimate: 75%; the middle value does not contradict the limit.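

Compound 3, like compound 1 and compound 2, gives only a limit in this assay, so neither step leading to compound 3 can be read as a size: the limit of > 50000 nM in this assay, at which 3 of the 3 values shown sit. The compounds shown leave open how far each lies from that limit, and whether exchanging the group on the aromatic nitrogen changes the result at all.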